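The compounds below may be only part of what the source reports. "The series", "measured", "known", "first", "only" and "open" are said of these compounds alone.

Measured so far in an in vitro assay on AV12 cells for binding affinity to Neuropeptide Y receptor type 1 (Homo sapiens); on this read-out higher numbers stand for weaker inhibition and lower numbers for stronger inhibition:
compound 1 `c1ccc(OCc2nc3c(OCCCN4CCCCC4)cccc3n2CCCC2CCN(CCC3CCCCC3)CC2)cc1` — 0.285 nM
compound 2 `CN1CCC(CCCn2c(COc3ccccc3)nc3c(OCCCN4CCCCC4)cccc32)CC1` — 1.62 nM

Compound 2 stands highest of the two numbers in this assay; its nearest neighbour is compound 1, with a 5.7-fold higher number from compound 1 to compound 2 (0.75 log units; beyond the scatter) between them. Compound 3 `c1ccc(OCc2nc3c(OCCCN4CCCCC4)cccc3n2CCCC2CCN(CC3CCCCC3)CC2)cc1` has not yet been measured. It differs from compound 2 by cyclohexyl in place of hydrogen on a saturated chain carbon bound to an amine nitrogen in a ring. Among the compounds with values here, the only step that bears on it is the one from compound 1 to compound 2, which runs the other way and removed a cyclohexylmethyl; here a cyclohexyl is put back in its place. A lowering of comparable size is therefore expected, a 4.1-fold lower number from compound 2 to compound 3 (0.61 log units; beyond the scatter), giving an estimate for compound 3 of 0.4 nM with a range of 0.15 nM to 1.1 nM.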

Compound 3, inhibition constant: 0.393 nM
Compound 3: the middle estimate sits 1.0-fold (0.01 log units) above what was measured, within the range that was stated.
By their numbers in this assay, from the lowest: compounds 1 and 3 (each within the scatter of the next); then compound 2.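

In this assay, methyl to cyclohexylmethyl at this position gives a step beyond the scatter (a 4.1-fold lower number from compound 2 to compound 3 (0.62 log units; beyond the scatter)). Cyclohexyl in place of cyclohexylmethyl on the same chain carbon stays within the scatter (a 1.4-fold higher number from compound 1 to compound 3 (0.14 log units; within the scatter)), so compound 1 and compound 3 cannot be told apart, and the two chain lengths carrying the cyclohexyl read alike here. No measured evidence on these steps is available to explain them.

Still open, on these data alone, is whether a longer chain carrying the cyclohexyl keeps this level. Also open, as far as these compounds go, is whether a phenyl ring can replace the cyclohexyl.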